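Aryl Swap on the Amine in a Cytotoxicity Series

A few compounds are considered here, and "the series" means these few. Any claim that something is new, unique, unknown or untested is made for them only; others in the source may bear on it.

Compound 2 `C=C1[C@@H](OC(C)=O)C[C@@H]2[C@](C)(COC=O)[C@H](OC(C)=O)CC[C@@]2(C)[C@@H]1C[C@@H](Nc1cccc2ccccc12)C1=CCOC1=O` and compound 1 `C=C1[C@@H](OC(C)=O)C[C@@H]2[C@](C)(COC=O)[C@H](OC(C)=O)CC[C@@]2(C)[C@@H]1C[C@@H](Nc1ccc(Br)cc1)C1=CCOC1=O` share one core and differ only in the aryl group on the amine nitrogen. For the measured compounds named here, in a functional assay on KB cells (Homo sapiens) for cytotoxicity, read by sulforhodamine B assay (on this read-out higher numbers stand for weaker inhibition and lower numbers for stronger inhibition), compound 1 gives 24000 nM, and compound 2 gives 32300 nM, the highest of the two numbers measured so far, though a 1.3-fold higher number from compound 1 to compound 2 (0.13 log units; within the scatter). Compound 3 `C=C1[C@@H](OC(C)=O)C[C@@H]2[C@](C)(COC=O)[C@H](OC(C)=O)CC[C@@]2(C)[C@@H]1C[C@@H](Nc1cccc(F)c1)C1=CCOC1=O` carries the change (3-fluorophenyl in place of naphthalen-1-yl on an amine nitrogen). Going by the values given here, the only step that bears on it is the one from compound 1 to compound 2, an exchange of one aryl group for another on the same nitrogen, and that step stayed within the scatter. One such step is a thin basis, but there is nothing in these numbers to suggest that another aryl exchange at this place would move the read-out beyond the scatter; the expected step is a 1.2-fold lower number from compound 2 to compound 3 (0.09 log units; within the scatter). Compound 3 is therefore estimated at 26000 nM, with a range from 10000 nM to 65000 nM.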

Compound 3, half-maximal inhibitory concentration: 28600 nM
Compound 3: the middle estimate sits 1.1-fold (0.04 log units) below what was measured; the range from low to high includes it.
By their numbers in this assay, from the lowest: compounds 1, 3 and 2 (each within the scatter of the next).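

In this assay, replacing naphthalen-1-yl with 3-fluorophenyl on the amine nitrogen gives a 1.1-fold lower number from compound 2 to compound 3 (0.05 log units; within the scatter), and replacing 4-bromophenyl with 3-fluorophenyl gives a 1.2-fold higher number from compound 1 to compound 3 (0.08 log units; within the scatter). A third aryl group, carrying fluorine rather than bromine, thus joins the other two within the scatter, so the read-out at this position now holds across three aryl groups, one with two aromatic rings and two with one. Nothing in the information available explains why these groups read alike.

All three groups on this nitrogen are aryl, which leaves open how a cyclohexyl group, a benzyl group or a phenyl ring carrying a carboxylic acid would read. Going by these compounds, it also remains open whether any change at this nitrogen would move the number beyond the scatter.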